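A few compounds are considered here, and "the series" means these few. Any claim that something is new, unique, unknown or untested is made for them only; others in the source may bear on it.

In a functional assay on KB cells (Homo sapiens) for antiproliferative activity, read by colorimetric assay and MTT assay (on this read-out lower numbers stand for stronger inhibition and higher numbers for weaker inhibition), compound 1 `O=[N+]([O-])c1ccc(S(=O)(=O)Nc2cccc3cc(O)[nH]c23)cc1` gives > 100 ug/mL, which is a limit of the assay and not a number. Compound 2 `N#Cc1ccc(S(=O)(=O)Nc2ccc(Cl)c3c(Cl)c[nH]c23)cc1` gives 13 ug/mL and compound 3 `Nc1ccc(S(=O)(=O)Nc2ccc(Cl)c3c(Cl)c[nH]c23)cc1` gives 14 ug/mL, so these two values lie within the scatter of each other. Compound 4 `Cc1ccc(NS(=O)(=O)c2ccc(N)cc2)c2[nH]cc(Cl)c12` has methyl in place of chloro on an aromatic carbon, para to a large group: methyl in place of chloro on an aromatic carbon. Going by the values given here, the only measured step, a 1.1-fold higher number from compound 2 to compound 3 (0.03 log units; within the scatter), exchanges amino for cyano at another place and so bears only indirectly on this change. Resting on compound 3 at 14 ug/mL, the expected size is none beyond the scatter, a 1.3-fold higher number from compound 3 to compound 4 (0.11 log units; within the scatter). For compound 4 the estimated value in this assay is 18 ug/mL, with an expected range of 7 ug/mL to 50 ug/mL.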

Compound 4, half-maximal inhibitory concentration: 16 ug/mL
Estimate against measurement, compound 4: 1.1-fold (0.05 log units) above; the measured number falls inside the stated range.
By their numbers in this assay, from the lowest: compounds 2, 3 and 4 (each within the scatter of the next). At a limit, above all of these: compound 1.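

With methyl in place of chloro on this aromatic carbon, para to a large group, this assay gives a 1.1-fold higher number from compound 3 to compound 4 (0.06 log units; within the scatter). Going by these compounds alone, the earlier step concerned another place, so this is the first reading here, and it shows that chloro is not needed at this position to keep the number of compound 3. Nothing measured here gives a cause for this result. Open, from the compounds shown here alone, is whether an amine, a methoxy group or a longer chain at this carbon would move the number beyond the scatter. Also open, going by these compounds, is how exchanging the chloro that remains in compound 4 would read.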